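Sulfone to Sulfide on a Shared Imidazoline Core

This account rests on a few compounds, and the source may have more. Where it says the series, first, only, none or still open, it means among the compounds named here.

Compound 1 `CSc1ccc(C)cc1NCC1=NCCN1` gives 200 nM in an assay on CHO cells for binding affinity to Alpha-2C adrenergic receptor (Homo sapiens), read by radioligand binding; on this read-out higher numbers stand for weaker inhibition and lower numbers for stronger inhibition.
Compound 2 `COc1ccc(SC)c(NCC2=NCCN2)c1` gives 603 nM in this assay.
Compound 3 `CS(=O)(=O)c1ccc(Cl)cc1NCC1=NCCN1` gives 4790 nM in this assay.

Compound 3 stands highest of the three numbers in this assay, beyond the scatter from compound 2 and further still from compound 1. Compound 4 `CSc1ccc(Cl)cc1NCC1=NCCN1` arises from compound 3 by methylsulfanyl in place of methylsulfonyl on an aromatic carbon. Among the compounds with values here, the only measured step, a 3.0-fold higher number from compound 1 to compound 2 (0.48 log units; beyond the scatter), concerns a different position and does not bear directly on this change. Yet compounds 1 and 2, which both carry the methylsulfanyl group that enters here, give far lower numbers than compound 3, so a marked drop in this assay is expected, roughly a 12-fold lower number from compound 3 to compound 4 (1.08 log units; beyond the scatter). Compound 4 is therefore estimated at 400 nM, within 150 nM to 1500 nM.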

Compound 4, inhibition constant: 170 nM
Compound 4: middle estimate off by 2.4-fold (0.37 log units), on the high side, and the stated range covers the measured number.
By their numbers in this assay, from the lowest: compounds 4 and 1 (each within the scatter of the next); then compound 2; then compound 3.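

Exchanging only the sulfur group on an otherwise unchanged compound gives a large step in this assay (a 28-fold lower number from compound 3 to compound 4 (1.45 log units; beyond the scatter)), so this position responds strongly to methylsulfonyl versus methylsulfanyl. With methylsulfanyl in place, the group para to it also matters, though unevenly: methoxy and chloro differ beyond the scatter (a 3.5-fold lower number from compound 2 to compound 4 (0.55 log units; beyond the scatter)), whereas methyl and chloro lie within it (a 1.2-fold lower number from compound 1 to compound 4 (0.07 log units; within the scatter)). Nothing available here explains these steps.

Going by these compounds, how an amine or a methylsulfinyl group would fare at this position stays open. So does whether the sulfur swap gives a similar step with methyl or methoxy in place of chloro.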